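A few compounds are considered here, and "the series" means these few. Any claim that something is new, unique, unknown or untested is made for them only; others in the source may bear on it.

Measured so far:
compound 1 `COc1cc(/C=C/C(=O)O)ccc1OC(=O)c1nc(C)c(C)nc1C` — 38.7%
compound 2 `COc1cc(/C=C/C(=O)O)cc(OC)c1OC(=O)c1nc(C)c(C)nc1C` — 5.7%

In a functional assay on EA.hy 926 cells (Homo sapiens) for cytotoxicity, read by MTT assay, with stated times of 24 h and 12 h, tested at 12.5 uM (on this read-out lower numbers stand for a weaker effect and higher numbers for a stronger effect at the one concentration tested), compound 1 gives 38.7% and stands highest of the two numbers; the nearest is compound 2 at 5.7%. Compound 3 `Cc1nc(C)c(C(=O)Oc2ccc(/C=C/C(=O)O)cc2)nc1C` differs from compound 1 by hydrogen in place of methoxy on an aromatic carbon. Within the data shown here, the one measured step that bears on this change is a number 33 percentage points lower from compound 1 to compound 2 (beyond the scatter), a large step in the opposite direction, where methoxy entered in place of hydrogen. Removing the methoxy is therefore expected to raise the read-out, with the expected step being a number 11.3 percentage points higher from compound 1 to compound 3 (beyond the scatter), though with wide uncertainty. Compound 3 is estimated at 50%, ranging from 25% to 75%.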

Compound 3, a percentage reported as activity, at one concentration (the size of the read-out at that concentration, not a potency): 34.2%
Compound 3: the middle estimate sits 15.8 percentage points above what was measured; the range from low to high includes it.
By their numbers in this assay, from the lowest: compound 2; then compounds 3 and 1 (each within the scatter of the next).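

In this assay, replacing the methoxy that sits ortho to a large group with hydrogen gives a number 4.5 percentage points lower from compound 1 to compound 3 (within the scatter), so on this read-out the two groups cannot be told apart at this position. The large step seen earlier, a number 33 percentage points lower from compound 1 to compound 2 (beyond the scatter), therefore does not apply in reverse to this change: removing this methoxy does not raise the read-out beyond the scatter. Nothing available explains this difference between the two steps.

On these data alone, whether an amine, a chlorine atom or a longer ethoxy chain on this aromatic carbon would move the read-out stays open. So does the effect of any such group with the carboxylic acid replaced by an ester.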